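This account rests on a few compounds, and the source may have more. Where it says the series, first, only, none or still open, it means among the compounds named here.

Measured so far:
compound 1 `CC(C)c1cccc(C(C)C)c1OC(=O)NC(=O)OC(c1ccccc1)c1ccccc1` — 350 nM
compound 2 `CCCCCCCCOC(=O)NC(=O)Oc1c(C(C)C)cccc1C(C)C` — 250 nM

Both numbers come from an assay on microsomes from intestine for inhibition of acyl-CoA:cholesterol acyltransferase (Oryctolagus cuniculus); on this read-out lower numbers stand for stronger inhibition and higher numbers for weaker inhibition. In this assay compound 2 gives 250 nM and stands with the lowest number of the two, though compound 1 with 350 nM sits within the scatter of it, so no order is claimed. Compound 3 `CCCCCCCCCCCCCCOC(=O)NC(=O)Oc1c(C(C)C)cccc1C(C)C` differs from compound 2 by hexyl in place of hydrogen on a saturated chain carbon, eight bonds along the chain from an oxygen next to a carbonyl group. Among the measured compounds shown here, no measured pair covers a change of this kind, so the expected step from compound 2 to compound 3 is a 1.3-fold lower number from compound 2 to compound 3 (0.10 log units; within the scatter), not beyond the scatter. Compound 3 is estimated at 200 nM, range 80 nM to 500 nM.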

Compound 3, half-maximal inhibitory concentration: 10 nM
Beside the measured number, compound 3's estimate is 20-fold (1.30 log units) above it; the whole stated range lies above it.
By their numbers in this assay, from the lowest: compound 3; then compounds 2 and 1 (each within the scatter of the next).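

At this saturated chain carbon, eight bonds along the chain from an oxygen next to a carbonyl group, hexyl in place of hydrogen gives a 25-fold lower number from compound 2 to compound 3 (1.40 log units; beyond the scatter) in this assay. Among the compounds shown here, the series therefore responds strongly to change at this position, which the earlier compounds, with no pair differing in one place, could not show. Nothing available explains the size of this step.

For the compounds shown here, with only one step, the shape of the dependence on chain length remains open, including whether a longer chain goes further. Also open, going by these compounds, is whether a chain ending in an amine or a carboxylic acid keeps this gain.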